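Benzothiophene amide series: nitrile for fluorine at compound 4

This account rests on a few compounds, and the source may have more. Where it says the series, first, only, none or still open, it means among the compounds named here.

Within the data shown here, compound 2 `O=C(NC1CCN(Cc2ccc(OC3CCNCC3)c(Br)c2)CC1)c1cc2cc(F)ccc2s1` gives 53 nM in an assay on HEK293 cells for displacement of a labelled ligand from Urotensin-2 receptor (Homo sapiens), read by fluorescence, with a stated time of 90 min (on this read-out higher numbers stand for weaker inhibition and lower numbers for stronger inhibition), the lowest of the three numbers measured so far. Compound 3 `O=C(NC1CCN(Cc2ccc(OC3CCNCC3)c(Br)c2)CC1)c1cc2cc(C(F)(F)F)ccc2s1` gives 100 nM, and a 1.9-fold higher number from compound 2 to compound 3 (0.28 log units; within the scatter), so the two cannot be told apart. Compound 1 `O=C(NC1CCN(Cc2ccc(OC3CCNCC3)c(Br)c2)CC1)c1ccco1` gives 770 nM; a 15-fold lower number from compound 1 to compound 2 (1.16 log units; beyond the scatter).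

Compound 4 `N#Cc1ccc2cc(C(=O)NC3CCN(Cc4ccc(OC5CCNCC5)c(Br)c4)CC3)sc2c1` carries 6-cyano-1-benzothiophen-2-yl in place of 5-fluoro-1-benzothiophen-2-yl on a carbonyl carbon. The bicyclic amide of compound 2 is kept; only the substituent on that ring system is exchanged. The measured step that bears most closely is the substituent swap within the same ring system, a 1.9-fold higher number from compound 2 to compound 3 (0.28 log units; within the scatter), which stayed inside the scatter. The large step of a 15-fold lower number from compound 1 to compound 2 (1.16 log units; beyond the scatter) concerns the ring system itself, which compound 4 retains, so it does not argue for a large move here. A small step is therefore expected for compound 4, a 1.4-fold higher number from compound 2 to compound 4 (0.15 log units; within the scatter), not clearly beyond the scatter and if anything towards a slightly higher number. Compound 4 is estimated at 75 nM, with a range from 30 nM to 250 nM.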

Compound 4, half-maximal inhibitory concentration: 80 nM
Compound 4: the middle estimate sits 1.1-fold (0.03 log units) below what was measured, and the stated range covers the measured number.
By their numbers in this assay, from the lowest: compounds 2, 4 and 3 (each within the scatter of the next); then compound 1.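

In this assay, the exchange of 5-fluoro-1-benzothiophen-2-yl for 6-cyano-1-benzothiophen-2-yl changes the group and its place on the ring system together, yet gives a 1.5-fold higher number from compound 2 to compound 4 (0.18 log units; within the scatter) and so leaves the two compounds indistinguishable. The second 1-benzothiophen-2-yl amide also keeps a gap to the furan-2-yl amide, with a 9.6-fold lower number from compound 1 to compound 4 (0.98 log units; beyond the scatter) in this assay, so compounds 2 and 4 both stand clear of compound 1 despite carrying different substituents. Nothing available offers an explanation for either step.

Open, as far as these compounds go, is whether the fluoro and nitrile groups each behave the same way when moved, since compounds 2 and 4 differ in group and place at once. Also open, from the compounds shown here alone, is how an amine or a carboxylic acid on the 1-benzothiophen-2-yl group would read in this assay and whether either would leave the number unchanged.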